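The source may report more compounds than this note shows. Statements on the series, on what has been measured and on what is new or still open speak of the compounds shown alone.

In a functional assay on SK-OV-3 cells (Homo sapiens) for cytotoxicity, read by resazurin assay (a lower number here means a stronger inhibitor, a higher number a weaker inhibitor), compound 1 `C#Cc1cccc(Nc2ncnc3ccc(OCc4ccc(C(=O)Nc5ccccc5N)cc4)cc23)c1` gives 5100 nM and compound 2 `C#Cc1cccc(Nc2ncnc3ccc(S(=O)(=O)n4ccc(/C=C/C(=O)Nc5ccccc5N)c4)cc23)c1` gives 5700 nM. Within the data shown here, these two values lie within the scatter of each other, so compound 2 stands level with compound 1 on the numbers so far. Among the measured compounds shown here, both compounds carry the 2-aminophenyl group on an amide-type nitrogen, and no measured compound lacks it.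

Compound 3 `C#Cc1cccc(Nc2ncnc3ccc(S(=O)(=O)n4ccc(/C=C/C(=O)NO)c4)cc23)c1` keeps the rest of compound 2 and changes one place: hydroxy in place of 2-aminophenyl on an amide-type nitrogen. In words, hydroxy stands in place of 2-aminophenyl on an amide-type nitrogen.

For the measured compounds named here, no measured pair shows this change, so the data give no direct guide to its size in this assay. The expectation rests on the structural change alone and remains a judgement, which calls for a wide range. A move to a lower number, beyond the scatter, is expected. The estimated size of that move is a 7.1-fold lower number from compound 2 to compound 3 (0.85 log units; beyond the scatter).

For compound 3 the expected value is 800 nM, with an estimated range of 150 nM to 4000 nM.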

Compound 3, half-maximal inhibitory concentration: 560 nM
Compound 3: the middle estimate sits 1.4-fold (0.15 log units) above what was measured; low and high end bracket the measured number.
By their numbers in this assay, from the lowest: compound 3; then compounds 1 and 2 (each within the scatter of the next).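

Until now every compound carried 2-aminophenyl on the amide-type nitrogen, so nothing showed whether this assay responds to a change at this place. Hydroxy in place of 2-aminophenyl gives a 10-fold lower number from compound 2 to compound 3 (1.01 log units; beyond the scatter) and is a large step, so this position is not a silent one in the series and the 2-aminophenyl group is not needed to reach the lower number. The change removes 7 heavy atoms and a six-membered aromatic ring and brings in 1 heavy atom, while the hydrogen-bond donor and acceptor counts stay the same, but no measurement here explains why the number moves.

Going by these compounds, the step rests on a single pair, so it remains open whether the gain belongs to hydroxy itself or would also appear with a small group such as methyl, methoxy or a plain amino group on the same nitrogen. Also open, on these data alone, is whether a carboxylic acid in place of hydroxycarbamoyl would hold the number, and whether the same hydroxy change on the core and linker of compound 1 would give a step of similar size.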